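The source may report more compounds than this note shows. Statements on the series, on what has been measured and on what is new or still open speak of the compounds shown alone.

In a functional assay on MCF7 cells (Homo sapiens) for cytotoxicity, read by MTT assay, with a stated time of 48 h (on this read-out higher numbers stand for weaker inhibition and lower numbers for stronger inhibition), compound 1 `Fc1cccc(-c2nc(Nc3ccccc3)c3cc(F)ccc3n2)c1` gives 49700 nM. For compound 2 `Fc1ccc(Nc2nc(-c3cccc(F)c3)nc3ccc(F)cc23)cc1` the same measurement reports only a limit, > 50000 nM. The step of a number no lower from compound 1 to compound 2 (the limit leaves the size open) therefore cannot be sized, since it runs into (the limit of > 50000 nM in this assay, at which 1 of the 2 values shown sits). Compound 3 `Fc1cccc(-c2nc(Nc3ccccc3Cl)c3cc(F)ccc3n2)c1` differs from compound 2 by 2-chlorophenyl in place of 4-fluorophenyl on a nitrogen on an aromatic ring. No measured step covers this change, and with compound 2 standing at a limit, no direction or size can be read from the shown steps. Compound 3 is expected to give about 50000 nM, between 20000 nM and 150000 nM, an expected step of a number no higher from compound 2 to compound 3 (the limit leaves the size open), with a good chance that only a limit is reported once more.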

Compound 3, half-maximal inhibitory concentration: > 50000 nM
Compound 3 gave a limit, no number (the forecaster's own chance of this, stated with the estimate: 60%); the middle value sits exactly at the limit.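

Compound 3 carries 2-chlorophenyl on the nitrogen, and in this assay it too reports only a limit, so the step from compound 2 cannot be read. The chloro group on that phenyl ring gives a number no lower from compound 1 to compound 3 (the limit leaves the size open), so this second change on the ring also shows no stronger inhibition. The values now gather at a single limit: the limit of > 50000 nM in this assay, at which 2 of the 3 values shown sit.

Still open, as far as these compounds go, is whether any group on this nitrogen gives a number clearly under that limit. A longer chain in place of the phenyl ring, or an amine on it, could answer that.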